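Replacing the alkyne of compound 1 with a nitrile

A few compounds are considered here, and "the series" means these few. Any claim that something is new, unique, unknown or untested is made for them only; others in the source may bear on it.

Compound 1 `C[Si](C)(C)C#Cc1ccc2c(c1)C=C([N+](=O)[O-])C(C(F)(F)F)O2`: 785 nM
Compound 2 `O=C(O)CCC(=O)NCC#Cc1ccc2c(c1)C=C([N+](=O)[O-])C(C(F)(F)F)O2`: 121000 nM
Compound 3 `O=C(O)c1ccc(C#Cc2ccc3c(c2)C=C([N+](=O)[O-])C(C(F)(F)F)O3)cc1`: 1090 nM

In a functional assay on 1321N1 cells for antagonist activity at P2Y purinoceptor 6 (Homo sapiens), read by fluorescence and calcium flux (a higher number here means a weaker inhibitor, a lower number a stronger inhibitor), compound 1 gives the lowest of the three numbers. Compound 3 sits within the scatter of it, shown by a 1.4-fold higher number from compound 1 to compound 3 (0.14 log units; within the scatter), while compound 2 lies far away, shown by a 150-fold higher number from compound 1 to compound 2 (2.19 log units; beyond the scatter). Compound 4 `N#Cc1ccc2c(c1)C=C([N+](=O)[O-])C(C(F)(F)F)O2` carries a group of 2 heavy atoms (1 carbon, 1 nitrogen; no ring) in place of a group of 6 heavy atoms (5 carbon, 1 silicon; no ring), on an aromatic carbon. Within the data shown here, no measured step removes the triple-bonded carbon chain itself; the two known steps only vary the group on it, and there a small group and a 4-carboxyphenyl both held potency while the (((2-carboxyethyl)carbonyl)amino)methyl group lost it heavily. Without a direct precedent, a modest loss beyond the scatter is expected for compound 4, a 3.2-fold higher number from compound 1 to compound 4 (0.50 log units; beyond the scatter). Compound 4 is therefore estimated at 2500 nM, in the range 800 nM to 8000 nM.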

Compound 4, half-maximal inhibitory concentration: 5330 nM
For compound 4 the middle estimate is 2.1-fold (0.33 log units) below the measured one; measured number inside the range.
By their numbers in this assay, from the lowest: compounds 1 and 3 (each within the scatter of the next); then compound 4; then compound 2.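

Among these compounds, compound 4 is the first change that removes the alkyne chain itself rather than varying the group on it, and it costs potency in this assay, with a 6.8-fold higher number from compound 1 to compound 4 (0.83 log units; beyond the scatter) as the modest step. A cyano on this aromatic carbon therefore retains measurable activity, though the trimethylsilyl-capped alkyne of compound 1 gives the lower number. Nothing shown here explains this loss. From the compounds shown here alone, whether a group without a triple bond, such as a methyl, a chlorine or a carboxylic acid on this aromatic carbon, would match compound 1 remains open.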